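Acetyl to dimethylamino on the shared core

The source may report more compounds than this note shows. Statements on the series, on what has been measured and on what is new or still open speak of the compounds shown alone.

Measured compounds in a functional assay on T47D cells (Homo sapiens) for inhibition, read by sulforhodamine B assay, with a stated time of 48 h; a higher number here means a weaker inhibitor of growth, a lower number a stronger inhibitor of growth:
compound 1, `COc1cc(C)cc(-c2c(-c3ccnc(-c4ccc(C(C)=O)cc4)c3)cnn2CC#N)c1`: 8020 nM
compound 2, `Cc1cc(O)cc(-c2nn(CC#N)cc2-c2ccnc(-c3ccc(Oc4ccccc4)cc3)c2)c1`: 5810 nM

Compound 1 has the highest number of the two in this assay; its nearest neighbour is compound 2, and the gap between them lies within the scatter, so the two values show no difference in growth inhibition that can be trusted. Both compounds inhibit growth only weakly in this assay.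

Compound 3, `COc1cc(C)cc(-c2c(-c3ccnc(-c4ccc(N(C)C)cc4)c3)cnn2CC#N)c1`, has not been measured in this assay. It differs from compound 1 in one place: dimethylamino in place of acetyl on an aromatic carbon. Going by the values given here, no measured pair shows this change, so nothing in the data fixes its size or direction. With both measured compounds sitting close together at weak inhibition, a step from compound 1 to compound 3 of no more than the scatter is expected, in either direction, as a 1.1-fold lower number from compound 1 to compound 3 (0.06 log units; within the scatter).

For compound 3 in this assay the estimated value is 7000 nM, expected to fall between 2500 nM and 20000 nM.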

Compound 3, concentration for total growth inhibition: > 100000 nM
Compound 3: no number, only a limit (the forecaster's own chance of this, stated with the estimate: 10%); middle value at least 14-fold (1.15 log units) from the limit.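

In this assay, compound 3 gives > 100000 nM, and this value is a limit of the assay, not a number. Dimethylamino in place of acetyl on the aromatic carbon para to a large group is a large step, an at least 12-fold higher number from compound 1 to compound 3 (1.09 log units; beyond the scatter), so the first direct comparison at this position shows that the group it carries can decide whether growth inhibition is seen in this assay at all, even though the two groups count the same number of heavy atoms and hydrogen-bond acceptors. The step therefore has a lower bound but no upper bound, and its true size cannot be read: the limit of > 100000 nM in this assay, at which 1 of the 3 values shown sits.

The compounds shown do not settle whether the acetyl group is needed for the weak inhibition of compound 1 or whether dimethylamino alone is unfavourable, since only these two groups can be compared at this position on the shared core. From the compounds shown here alone, how a carboxylic acid, a primary amide, a morpholine ring or a plain hydrogen would read at the same place remains open, as does whether the step holds on any other core.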